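A few compounds are considered here, and "the series" means these few. Any claim that something is new, unique, unknown or untested is made for them only; others in the source may bear on it.

Measured compounds:
compound 1, `O=c1ccoc2cc(OCc3cn(Cc4ccccc4)nn3)ccc12`: > 100000 nM
compound 2, `O=c1ccoc2cc(OCc3cn(Cc4ccccc4Br)nn3)ccc12`: > 100000 nM

Both values come from a functional assay on SGC-7901 cells (Homo sapiens) for cytotoxicity, read by MTT assay, with a stated time of 48 h; on this read-out higher numbers stand for weaker inhibition and lower numbers for stronger inhibition. For compound 1 the value > 100000 nM is a limit of the assay and not a number. For compound 2 the value > 100000 nM is likewise a limit. Going by the values given here, the step from compound 1 to compound 2 therefore reads a step that the two limits leave unreadable from compound 1 to compound 2, and the only evidence bearing on it is the limit of > 100000 nM in this assay, at which 2 of the 2 values shown sit. Compound 3, `COc1ccc(Cn2cc(COc3ccc4c(=O)ccoc4c3)nn2)cc1`, is not yet measured in this assay; it differs from compound 2 by 4-methoxyphenyl in place of 2-bromophenyl on a saturated chain carbon bound to an aromatic nitrogen. Among the compounds with values here, no measured step concerns this change, and the one step known, a step that the two limits leave unreadable from compound 1 to compound 2, gives no size at all. Compound 2 stands at a limit of the assay. Compound 3 is expected to sit near that same limit, with an expected step of a number no higher from compound 2 to compound 3 (the limit leaves the size open) that no shown step can size. The estimate for compound 3 is 100000 nM, between 30000 nM and 300000 nM.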

Compound 3, half-maximal inhibitory concentration: > 100000 nM
Compound 3 ended at the assay's limit; the forecaster's own chance of this, stated with the estimate: 80%; the middle value sits exactly at the limit.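

Compound 3 gives only a limit in this assay, not a number, as do compound 1 and compound 2, so no new step can be read among them: the limit of > 100000 nM in this assay, at which 3 of the 3 values shown sit.

The compounds shown leave open how these three rank against one another in this assay.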